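The source may report more compounds than this note shows. Statements on the series, on what has been measured and on what is new or still open speak of the compounds shown alone.

Compound 1 `COC(=O)c1cccc(C)c1OC(=O)COc1cc(O)c2c(=O)cc(-c3ccccc3)oc2c1` and compound 2 `COC(=O)c1c(C)cccc1OC(=O)COc1cc(O)c2c(=O)cc(-c3ccccc3)oc2c1` share one core and differ only in the group attached to an oxygen next to a carbonyl group. In a functional assay on cells (T-cell, Mus musculus, strain BALB/c) for inhibition, read by MTT assay, with a stated time of 72 h (on this read-out lower numbers stand for stronger inhibition and higher numbers for weaker inhibition), compound 1 gives 39100 nM and compound 2 gives 37200 nM. The step of a 1.1-fold lower number from compound 1 to compound 2 (0.02 log units; within the scatter) lies within the scatter. Within the data shown here, on the two numbers so far, compound 2 has the lowest value, but only by an amount within the scatter, so it is not separable from compound 1.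

Compound 3 `COC(=O)c1cc(F)ccc1OC(=O)COc1cc(O)c2c(=O)cc(-c3ccccc3)oc2c1` changes the same place again: a group of 11 heavy atoms (8 carbon, 2 oxygen, 1 fluorine; one six-membered aromatic ring of carbon only) in place of a group of 11 heavy atoms (9 carbon, 2 oxygen; one six-membered aromatic ring of carbon only), on an oxygen next to a carbonyl group. Among the measured compounds shown here, the single measured step bearing on this, a 1.1-fold lower number from compound 1 to compound 2 (0.02 log units; within the scatter), swapped one such ring group for another and stayed within the scatter, so no step beyond the scatter is expected in this assay. Compound 3 is therefore expected to give 37000 nM, ranging from 18000 nM to 75000 nM. For compound 3 this means an expected step of a 1.0-fold lower number from compound 2 to compound 3 (0.00 log units; within the scatter).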

Compound 3, half-maximal inhibitory concentration: 6820 nM
Beside the measured number, compound 3's estimate is 5.4-fold (0.73 log units) above it, outside the stated range (below it).
By their numbers in this assay, from the lowest: compound 3; then compounds 2 and 1 (each within the scatter of the next).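

In this assay the group on an oxygen next to a carbonyl group turns out to matter: the swap to the fluorine-bearing ring group gives a 5.5-fold lower number from compound 2 to compound 3 (0.74 log units; beyond the scatter) and also a 5.7-fold lower number from compound 1 to compound 3 (0.76 log units; beyond the scatter) in this series. So this place can respond to a change of ring group, which the first pair did not reveal. No measurement here explains why.

Compound 3 carries fluorine and lacks the methyl of compound 1 and compound 2, so the two changes cannot be told apart. On these data alone, whether a chlorine or an amine on that ring would give a lower number remains open.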